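Pyrrolyl Enones Against Cytochrome P450 1A1: Compound 4 Expected

This account rests on a few compounds, and the source may have more. Where it says the series, first, only, none or still open, it means among the compounds named here.

Measured so far:
compound 1 `COc1ccc(/C=C/C=C/C(=O)c2ccc[nH]2)cc1` — > 20000 nM
compound 2 `O=C(/C=C/c1cc([N+](=O)[O-])ccc1Cl)c1ccc[nH]1` — > 20000 nM
compound 3 `O=C(O)c1ccc(/C=C/C(=O)c2ccc[nH]2)cc1` — > 20000 nM

Of the compounds shown here, three sharing the pyrrolyl enone core have been tested in an assay for inhibition of cytochrome P450 1A1 (Homo sapiens), read by fluorescence, using microsomes, with a stated time of 10 min; on this read-out higher numbers stand for weaker inhibition and lower numbers for stronger inhibition. Compound 1 `COc1ccc(/C=C/C=C/C(=O)c2ccc[nH]2)cc1` reports only a limit, > 20000 nM. Compound 2 `O=C(/C=C/c1cc([N+](=O)[O-])ccc1Cl)c1ccc[nH]1` likewise reports a limit, > 20000 nM. Compound 3 `O=C(O)c1ccc(/C=C/C(=O)c2ccc[nH]2)cc1` too reports a limit in this assay, > 20000 nM, so its standing is known only as this limit, with nothing to separate it from the others: the limit of > 20000 nM in this assay, at which 3 of the 3 values shown sit.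

The next compound, compound 4 `O=C(/C=C/c1ccc(OC(F)(F)F)cc1)c1ccc[nH]1`, differs from compound 3 in one place: trifluoromethoxy in place of carboxy on an aromatic carbon. Going by the values given here, no measured step between compounds is available to size this change, so the expectation rests on the shared limit alone. Since all values stop at the limit, compound 4 is expected to give a value near that limit as well, with a fair chance that this assay again returns only a limit. The expected step is an at least 1.3-fold lower number from compound 3 to compound 4 (0.12 log units; that floor lies within the scatter). For compound 4 the estimate in this assay is 15000 nM, ranging from 3000 nM to 60000 nM.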

Compound 4, half-maximal inhibitory concentration: > 20000 nM
Compound 4: no number, only a limit (the forecaster's own chance of this, stated with the estimate: 60%); at least 1.3-fold (0.12 log units) between middle value and limit.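

Going by these compounds alone, compound 4 also reports only a limit, > 20000 nM, so no step from compound 3 to compound 4 can be read. The compounds shown leave open how strongly any of them inhibits the enzyme, and whether any change on the shared core would give a readable value.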